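The source may report more compounds than this note shows. Statements on the series, on what has been measured and on what is new or still open speak of the compounds shown alone.

In a functional assay on SK-BR-3 cells (Homo sapiens) for antiproliferative activity, read by MTT assay, with a stated time of 72 h (a lower number here means a stronger inhibitor, a higher number a weaker inhibitor), three compounds built on one shared core have been measured so far. Compound 1 `CCN1CCN(c2cc(C)c3cc(NC(=O)c4ccccc4C)ccc3n2)CC1` gives 29200 nM and compound 2 `CCN1CCN(c2cc(C)c3cc(NC(=O)c4ccccc4Br)ccc3n2)CC1` gives 39200 nM. Exchanging methyl for bromo on the aromatic ring barely registers: a 1.3-fold higher number from compound 1 to compound 2 (0.13 log units; within the scatter). Compound 3 `CCN1CCN(c2cc(C)c3cc(NC(=O)c4cc5ccccc5[nH]4)ccc3n2)CC1`, which carries 1H-indol-2-yl on the carbonyl carbon, has the lowest number of the three at 2550 nM. It is clearly separated from both others, as an 11-fold lower number from compound 1 to compound 3 (1.06 log units; beyond the scatter) and a 15-fold lower number from compound 2 to compound 3 (1.19 log units; beyond the scatter) show.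

Compound 4 `CCN1CCN(c2cc(C)c3cc(NC(=O)c4cccc(Br)c4)ccc3n2)CC1` gives up the group that sets compound 3 apart: 3-bromophenyl in place of 1H-indol-2-yl on a carbonyl carbon. In short, 3-bromophenyl takes the place of 1H-indol-2-yl on a carbonyl carbon. The two large steps bear most directly on this change, since each replaced a substituted phenyl group with 1H-indol-2-yl, and compound 4 runs in the opposite direction. A clear rise in the number is therefore expected, beyond the scatter. Among the compounds with values here, the bromine in compound 4 does not sit where it sits in compound 2, and no measured compound shows what that difference does, so the rise may be smaller and the range is kept wide. The expected change is a 6.3-fold higher number from compound 3 to compound 4 (0.80 log units; beyond the scatter). For compound 4 the estimated value is 16000 nM, with an expected range from 5000 nM to 45000 nM.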

Compound 4, half-maximal inhibitory concentration: 13300 nM
For compound 4 the middle estimate is 1.2-fold (0.08 log units) above the measured one; measured number inside the range.
By their numbers in this assay, from the lowest: compound 3; then compound 4; then compounds 1 and 2 (each within the scatter of the next).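

In this assay, the new step shows that 1H-indol-2-yl keeps its advantage over a third substituted phenyl group (this time 3-bromophenyl), although by less than in the earlier large steps (a 5.2-fold higher number from compound 3 to compound 4 (0.72 log units; beyond the scatter)). It also shows that the phenyl groups on this carbonyl carbon are not interchangeable, which the earlier methyl-for-bromo step within the scatter could not reveal: 3-bromophenyl does better than both 2-bromophenyl (a 2.9-fold lower number from compound 2 to compound 4 (0.47 log units; beyond the scatter)) and 2-methylphenyl (a 2.2-fold lower number from compound 1 to compound 4 (0.34 log units; beyond the scatter)), so compound 4 falls between compound 3 and the other two. Nothing measured here explains why these groups differ.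

The compounds shown leave open whether the advantage of 1H-indol-2-yl depends on its second ring or on the hydrogen of its ring nitrogen, a question that an indole with a methyl group on that nitrogen could help to answer. They also leave open how far a phenyl group can go at this carbonyl carbon, for instance with an amine or a carboxylic acid on the ring, or with no substituent at all.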